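The compounds below may be only part of what the source reports. "The series", "measured", "known", "first", "only" and "open" are said of these compounds alone.

In an assay for inhibition of Indoleamine 2,3-dioxygenase 1 (Homo sapiens), with stated times of 10 min and 60 min, tested at 10 uM (a higher number here means a stronger effect of the compound at the concentration tested, a lower number a weaker effect), the three measured compounds gave:

- compound 1, `NCCn1ncc2c(NCc3ccccc3[N+](=O)[O-])cc(C(F)(F)F)cc21`: 9%
- compound 2, `N#Cc1cc(NCc2ccccc2[N+](=O)[O-])c2cn[nH]c2c1`: 7%
- compound 3, `O=[N+]([O-])c1ccccc1CNc1cc(Br)cc2[nH]ncc12`: 67%

Compound 3 gives the highest of the three numbers in this assay, and its lead over both compound 1 and compound 2 lies beyond the scatter. Among the compounds with values here, the one measured step that changes a single place is a number 60 percentage points higher from compound 2 to compound 3 (beyond the scatter); it shows that the group at this position of the shared core can move the read-out a long way. Within the data shown here, compound 1 carries a trifluoromethyl at that same position but also a chain on the core nitrogen, so its value shows only that this combination gives a weak read-out; no single-place step links it to compound 3.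

Compound 4, `O=[N+]([O-])c1ccccc1CNc1cc(C(F)(F)F)cc2[nH]ncc12`, differs from compound 3 as follows: trifluoromethyl in place of bromo on an aromatic carbon. No measured step tests bromo against trifluoromethyl at this position, so the expected step of a number 22 percentage points lower from compound 3 to compound 4 (beyond the scatter) is uncertain in direction; the large cyano-to-bromo step warns that the read-out may shift strongly, while the weak number of compound 1 leaves open whether the trifluoromethyl itself is the cause. On that basis compound 4 is estimated at 45%, within a wide range from 10% to 80%.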

Compound 4, a percentage reported as inhibition, at one concentration (the size of the read-out at that concentration, not a potency): 35%
For compound 4 the middle estimate is 10 percentage points above the measured one; the measured number falls inside the stated range.
By their numbers in this assay, from the lowest: compounds 2 and 1 (each within the scatter of the next); then compound 4; then compound 3.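

In this assay the shared core now carries three different groups at this position, so they can be placed in order rather than only compared in a single pair. Trifluoromethyl in place of bromo gives a number 32 percentage points lower from compound 3 to compound 4 (beyond the scatter) while trifluoromethyl in place of cyano gives a number 28 percentage points higher from compound 2 to compound 4 (beyond the scatter) and this puts trifluoromethyl in the middle, with bromo highest and cyano lowest among these three groups. The low number of compound 1 also gains a clearer reading: with trifluoromethyl kept in place, hydrogen in place of 2-aminoethyl on an aromatic nitrogen gives a number 26 percentage points higher from compound 1 to compound 4 (beyond the scatter) and so trifluoromethyl alone does not account for that low number.

On these data alone, it remains open whether chlorine, iodine, a methyl group or a methoxy group at this position would reach the level of bromo, and whether a methyl group or a 2-hydroxyethyl chain on the aromatic nitrogen would lower the number as 2-aminoethyl does. Nothing measured here explains why the three groups fall in this order.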